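The source may hold more compounds than are shown below. What is called first, only, known or untested is meant among the compounds shown, and "the series" means these compounds.

Measured in a functional assay on CHO cells with adenosine receptor A1 (Homo sapiens) as the target, read by cAMP accumulation and immunoassay, with a stated time of 6 min, tested at 10 uM; a higher number here means a weaker effect of the compound at the concentration tested, a lower number a stronger effect:
- compound 1, `Nc1scc(CN2CCN(c3ccc(OC(F)(F)F)cc3)CC2)c1C(=O)c1ccc(Cl)cc1`, gives -74%
- compound 2, `Nc1scc(CN2CCN(c3cccc(Cl)c3)CC2)c1C(=O)c1ccc(Cl)cc1`, gives -77%

Compound 1 and compound 2 share one core and differ only in the group on the ring nitrogen. On the numbers shown, compound 1 sits at the same level as compound 2: the step of a number 3 percentage points lower from compound 1 to compound 2 (within the scatter) is within the scatter, so the two values cannot be told apart.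

Compound 3, `Nc1scc(CN2CCN(c3ccc(Cl)c(Cl)c3)CC2)c1C(=O)c1ccc(Cl)cc1`, is not yet measured. Its change from compound 1 is 3,4-dichlorophenyl in place of 4-(trifluoromethoxy)phenyl on an amine nitrogen in a ring.

Going by the values given here, the only measured step that bears on this change is the one from compound 1 to compound 2, where a chlorine-bearing phenyl also replaced the 4-(trifluoromethoxy)phenyl, and that step was within the scatter. Nothing in the data therefore points to a step beyond the scatter in this assay for compound 3; the expectation is a value close to both measured ones.

The estimate for compound 3 in this assay is -76%, with a range from -92% to -58%. The expected step from compound 1 is a number 2 percentage points lower from compound 1 to compound 3 (within the scatter).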

Compound 3, a percentage reported as activity, at one concentration (the size of the read-out at that concentration, not a potency): -62%
The estimate for compound 3 lay 14 percentage points below the measured number, within the range that was stated.
By their numbers in this assay, from the lowest: compounds 2 and 1 (each within the scatter of the next); then compound 3.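

In this assay, going by these compounds alone, the phenyl group on an amine nitrogen in a ring turns out to be less forgiving than the first pair of compounds suggested: placing 3,4-dichlorophenyl there instead of 4-(trifluoromethoxy)phenyl gives a number 12 percentage points higher from compound 1 to compound 3 (beyond the scatter) and so a modestly weaker effect at the concentration tested. Within the data shown here, the tightest comparison is the one with a single change, chloro in place of hydrogen on an aromatic carbon, which gives a number 15 percentage points higher from compound 2 to compound 3 (beyond the scatter) and shows that one added chloro on this phenyl can move the read-out beyond the scatter, whereas the earlier swap of whole phenyl groups did not. Nothing available explains why this added chloro weakens the effect.

The compounds shown leave open whether the weakening belongs to chloro itself or would also follow from another small group in its place, such as methyl, methoxy or nitrile. They also leave open how a plain phenyl with no group on it would compare, which would show how much any of these groups matters in this position.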